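The source may report more compounds than this note shows. Statements on the series, on what has been measured and on what is new or still open speak of the compounds shown alone.

In a functional assay on K562 cells (Homo sapiens) for cytotoxicity, read by MTT assay, with a stated time of 48 h (a lower number here means a stronger inhibitor, a higher number a weaker inhibitor), compound 1 `O=C(CN[C@H]1CCN(S(=O)(=O)Cc2ccccc2)C1)N1CCN(Cc2ccccc2Cl)CC1` gives 9000 nM. For the measured compounds named here, compound 2 `O=C(CN[C@H]1CCN(S(=O)(=O)Cc2ccccc2)C1)N1CCN(Cc2c(Cl)cccc2Cl)CC1` gives 28400 nM, the higher of the two numbers so far. Compound 3 `O=C(CN[C@H]1CCN(S(=O)(=O)Cc2ccccc2)C1)N1CCN(Cc2c(F)cccc2Cl)CC1` is the next step: fluoro in place of chloro on an aromatic carbon. This is fluoro in place of chloro on an aromatic carbon, ortho to a large group and meta to a chloro group, turning 2,6-dichlorobenzyl into 2-chloro-6-fluorobenzyl. Going by the values given here, one measured step bears on this change: chloro in place of hydrogen on an aromatic carbon, a 3.2-fold higher number from compound 1 to compound 2 (0.50 log units; beyond the scatter), modest in size. Among the compounds with values here, no fluoro analogue has been measured, so this comparison is only a rough guide. In this assay, a smaller shift toward a lower number is expected, possibly within the scatter. The expected step is a 1.8-fold lower number from compound 2 to compound 3 (0.25 log units; within the scatter). The estimate for compound 3 is 16000 nM, with an expected range of 8000 nM to 32000 nM.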

Compound 3, half-maximal inhibitory concentration: 65800 nM
Compound 3: middle estimate off by 4.1-fold (0.61 log units), on the low side, and the stated range ends below it.
By their numbers in this assay, from the lowest: compound 1; then compound 2; then compound 3.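

In this assay, fluoro in place of chloro at this position does not bring the number back toward the hydrogen compound but moves it further away, with a 2.3-fold higher number from compound 2 to compound 3 (0.36 log units; beyond the scatter). Measured against hydrogen, the fluoro group gives a 7.3-fold higher number from compound 1 to compound 3 (0.86 log units; beyond the scatter), a larger step than a 3.2-fold higher number from compound 1 to compound 2 (0.50 log units; beyond the scatter), so from the lowest number the order at this position is hydrogen, chloro, fluoro, and the two halogens are not interchangeable here. No measurement among these data accounts for this order.

From the compounds shown here alone, whether the order extends beyond these three groups stays open: a methyl, a methoxy or an amine at this position could fall anywhere relative to them. Going by these compounds, it is also open whether the fluoro step would be the same if the chloro group on the other side of the ring gave way to hydrogen.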